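Methoxy added to compound 2: working notes

This account rests on a few compounds, and the source may have more. Where it says the series, first, only, none or still open, it means among the compounds named here.

In a functional assay on K562 cells (Homo sapiens) for cytotoxicity, read by trypan blue exclusion, with a stated time of 96 h (a lower number here means a stronger inhibitor, a higher number a weaker inhibitor), compound 2 (`COc1ccc(CS(=O)(=O)/C=C/c2ccccc2OC)cc1N`) gives 7500 nM, the second highest of three numbers. Compound 1 (`COc1ccccc1/C=C/S(=O)(=O)Cc1ccc(OC)c([N+](=O)[O-])c1`) stands higher at 20000 nM, and compound 3 (`COc1ccc(/C=C/S(=O)(=O)Cc2ccc(OC)c(N)c2)c(OC)c1`) stands lower at 500 nM.

Compound 4 (`COc1ccc(OC)c(/C=C/S(=O)(=O)Cc2ccc(OC)c(N)c2)c1`) departs from compound 2 by a single change: methoxy in place of hydrogen on an aromatic carbon. The incoming methoxy sits on an aromatic carbon, meta to a large group and para to a methoxy group.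

For the measured compounds named here, the closest precedent is a 15-fold lower number from compound 2 to compound 3 (1.18 log units; beyond the scatter), a large step that also comes from methoxy in place of hydrogen on an aromatic carbon. The other measured step, a 2.7-fold lower number from compound 1 to compound 2 (0.43 log units; beyond the scatter), is modest and comes from amino in place of nitro on an aromatic carbon, so it says little about this change. The precedent is one case only, and the data do not show how far it carries to the place taken in compound 4. A lower number than that of compound 2 is therefore expected in this assay, beyond the scatter but probably short of the full precedent.

The expected change is a 5.0-fold lower number from compound 2 to compound 4 (0.70 log units; beyond the scatter).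

For compound 4 the estimated value is 1500 nM, with an expected range from 300 nM to 7000 nM.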

Compound 4, half-maximal inhibitory concentration: 750 nM
Beside the measured number, compound 4's estimate is 2.0-fold (0.30 log units) above it; measured number inside the range.
By their numbers in this assay, from the lowest: compounds 3 and 4 (each within the scatter of the next); then compound 2; then compound 1.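

In this assay the methoxy in place of hydrogen again lowers the number beyond the scatter, with a 10-fold lower number from compound 2 to compound 4 (1.00 log units; beyond the scatter) set against a 15-fold lower number from compound 2 to compound 3 (1.18 log units; beyond the scatter) for the same kind of change at another place on the ring, so the gain no longer rests on one case. On an aromatic carbon meta to a large group and para to a methoxy group the added methoxy serves about as well as at the place taken in compound 3, since compound 3 at 500 nM and compound 4 at 750 nM lie within the scatter of each other, and this assay does not separate these two places. Nothing measured here bears on what lies behind the lower number at either place.

The compounds shown do not tell whether the methoxy itself matters at this place, or whether a hydroxyl, an ethoxy or a fluorine would give a similar number. They also leave open whether methoxy groups at both places together would lower the number further than either does alone, and whether the same holds with the nitro of compound 1 in place of the amino.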